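The source may report more compounds than this note shows. Statements on the series, on what has been measured and on what is new or still open speak of the compounds shown alone.

Working notes on the series. Of the compounds shown here, two sharing one core have numbers so far in a functional assay on A549 cells (Homo sapiens) for cytotoxicity, read by MTT assay, with a stated time of 68 h; on this read-out lower numbers stand for stronger inhibition and higher numbers for weaker inhibition: compound 1 (`O=C(Nc1cccc(-c2cccs2)c1)C(Cl)Cl`) gives 47600 nM, and compound 2 (`O=C(Nc1cccc(-c2ccccc2)c1)C(Cl)Cl`) gives 8900 nM. Among the measured compounds shown here, compound 2 therefore holds the lower of the two numbers, with compound 1 as its only neighbour.

Next is compound 3 (`O=C(Nc1cccc(-c2ccoc2)c1)C(Cl)Cl`), which carries furan-3-yl in place of phenyl on an aromatic carbon, meta to a ((dichloromethyl)carbonyl)amino group: furan-3-yl in place of phenyl on an aromatic carbon.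

For the measured compounds named here, only one measured step bears on this change: a 5.3-fold lower number from compound 1 to compound 2 (0.73 log units; beyond the scatter), a modest step beyond the scatter, with phenyl in place of thiophen-2-yl. Going by the values given here, it is the only measured exchange at this place, and no furan-bearing compound has a number yet, so the support is thin. Leaving phenyl is expected to move the number up, by a modest amount no larger than that step. The expected change is a 2.7-fold higher number from compound 2 to compound 3 (0.43 log units; beyond the scatter).

For compound 3 the estimate in this assay is 24000 nM, with an expected range of 9000 nM to 60000 nM.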

Compound 3, half-maximal inhibitory concentration: 8480 nM
Beside the measured number, compound 3's estimate is 2.8-fold (0.45 log units) above it; the whole stated range lies above it.
By their numbers in this assay, from the lowest: compounds 3 and 2 (each within the scatter of the next); then compound 1.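

In this assay, the exchange at this aromatic carbon gives a 1.0-fold lower number from compound 2 to compound 3 (0.02 log units; within the scatter), so furan-3-yl, a five-membered aromatic ring with 1 hetero atom, and phenyl, a six-membered aromatic ring of carbon only, cannot be told apart here. The step with furan-3-yl in place of thiophen-2-yl is a 5.6-fold lower number from compound 1 to compound 3 (0.75 log units; beyond the scatter), which shows that a five-membered aromatic ring at this place does not by itself bring the higher number seen for compound 1; among the three compounds, compound 1 alone stands apart. No measurement in hand accounts for this separation of compound 1 from compound 2 and compound 3.

Thiophen-2-yl and furan-3-yl differ in both the hetero atom and the point of attachment, so these compounds leave open which of the two goes with the step, a question that furan-2-yl or thiophen-3-yl at the same place could address. Also open, from the compounds shown here alone, is how this place responds to a ring or chain carrying an amine or a carboxylic acid, and whether the parity of compound 2 and compound 3 holds for other replacements of phenyl.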